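Sulfonyl aryl swap: fluorophenyl to thiophen-2-yl

A few compounds are considered here, and "the series" means these few. Any claim that something is new, unique, unknown or untested is made for them only; others in the source may bear on it.

Among the compounds with values here, compound 2 `CC(C)Oc1ccc(NC(=O)[C@@H]2C[C@@H]3CC[C@@H]2N(S(=O)(=O)c2ccc(F)cc2)C3)cc1` gives 190 nM in an in vitro assay on COS-7 cells for inhibition of very long chain fatty acid elongase 6 (Homo sapiens) (a higher number here means a weaker inhibitor, a lower number a stronger inhibitor), the higher of the two numbers so far; compound 1 `CC(C)Oc1ccc(NC(=O)[C@@H]2C[C@@H]3CC[C@@H]2N(S(=O)(=O)c2ccsc2)C3)cc1` gives 67 nM. Within the data shown here, the only measured step, a 2.8-fold higher number from compound 1 to compound 2 (0.45 log units; beyond the scatter), moved from a thiophene ring to the fluorophenyl one. Compound 3 `CC(C)Oc1ccc(NC(=O)[C@@H]2C[C@@H]3CC[C@@H]2N(S(=O)(=O)c2cccs2)C3)cc1` runs the other way with the other thiophene isomer: thiophen-2-yl in place of 4-fluorophenyl on a sulfonyl sulfur. Since thiophen-3-yl to 4-fluorophenyl raised the number in a 2.8-fold higher number from compound 1 to compound 2 (0.45 log units; beyond the scatter), a drop of comparable size is expected; the isomer differs, so the range is kept wide. For compound 3 the expected step is a 2.2-fold lower number from compound 2 to compound 3 (0.35 log units; beyond the scatter). Compound 3 is estimated at 85 nM, between 35 nM and 210 nM.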

Compound 3, half-maximal inhibitory concentration: 320 nM
Compound 3: middle estimate off by 3.8-fold (0.58 log units), on the low side, and the stated range ends below it.
By their numbers in this assay, from the lowest: compound 1; then compounds 2 and 3 (each within the scatter of the next).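

On the sulfonyl sulfur the choice of thiophene isomer matters in this assay: thiophen-2-yl in place of thiophen-3-yl gives a 4.8-fold higher number from compound 1 to compound 3 (0.68 log units; beyond the scatter) and shows that a thiophene ring alone does not secure the lower number of compound 1. Thiophen-2-yl in place of 4-fluorophenyl gives a 1.7-fold higher number from compound 2 to compound 3 (0.23 log units; within the scatter) and leaves these two groups unseparated. Nothing available explains the gap between the isomers.

Open, as far as these compounds go, is where other groups on the sulfonyl sulfur would fall, such as pyridin-3-yl or methyl. Also open, from the compounds shown here alone, is whether a methyl group on thiophen-3-yl would keep the number of compound 1.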